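The source may hold more compounds than are shown below. What is called first, only, known or untested is meant among the compounds shown, and "the series" means these compounds.

Measured so far:
- compound 1 `Cc1ccccc1OS(=O)(=O)c1ccc(N2CCN(C)C2=O)cc1`: 5600 nM
- compound 2 `CN1CCN(c2ccc(S(=O)(=O)Oc3cc(Cl)c(Cl)cc3Cl)cc2)C1=O`: 630 nM

In a functional assay on MCF7 cells (Homo sapiens) for antiproliferative activity, read by sulforhodamine B assay, with a stated time of 48 h (a lower number here means a stronger inhibitor, a higher number a weaker inhibitor), compound 1 gives 5600 nM, the highest of the two numbers in hand. Compound 2 gives 630 nM in the same assay, a lower number, and the gap between the two lies beyond the scatter. The two compounds differ in more than one place, so the data show only what their two values say.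

Compound 3 `Cc1ccc(OS(=O)(=O)c2ccc(N3CCN(C)C3=O)cc2)cc1` is not yet measured. It differs from compound 1 as follows: 4-methylphenyl in place of 2-methylphenyl on an oxygen. The two have the same atoms, joined differently. Among the measured compounds shown here, no pair of measured compounds covers a move of this kind, so the size of the step is open. The expectation is a step of no more than the usual scatter, if anything towards a lower number. Compound 3 is estimated at 4000 nM, within 1500 nM to 12000 nM, which means an expected step of a 1.4-fold lower number from compound 1 to compound 3 (0.15 log units; within the scatter).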

Compound 3, half-maximal inhibitory concentration: > 100000 nM
Compound 3: a limit, no number (the forecaster's own chance of this, stated with the estimate: 5%); middle value at least 25-fold (1.39 log units) away from the limit.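

In this assay, exchanging 2-methylphenyl for 4-methylphenyl on the oxygen attached to the sulfonyl sulfur is far from a silent change between two compounds with the same atoms: it gives an at least 17-fold higher number from compound 1 to compound 3 (1.25 log units; beyond the scatter). Compound 3 reads > 100000 nM, which is a limit of the assay and not a number: the limit of > 100000 nM in this assay, at which 1 of the 3 values shown sits. Where the methyl group sits on this phenyl group is thus enough on its own to separate a measurable value from the limit, something that compound 1 and compound 2, which differ in more than one place, could not show.

As far as these compounds go, it remains open whether 3-methylphenyl, 4-methoxyphenyl or 4-aminophenyl on the same oxygen would read like compound 1 or like compound 3. From the compounds shown here alone, this rests on one pair, so it is also open whether the same move would have a similar effect on other phenyl groups at this oxygen.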